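From 2-fluoropyridin-3-yl to 3,5-difluorophenyl

A few compounds are considered here, and "the series" means these few. Any claim that something is new, unique, unknown or untested is made for them only; others in the source may bear on it.

Of the compounds shown here, two with a shared core have been measured in an ADME assay on the whole organism (Mus musculus, strain Swiss Webster) for pharmacokinetics, read by LC-MS, at a dose of 50 mg/kg by the oral route; a higher number here means more compound in the circulation at the dose given, a lower number less compound in the circulation. Compound 1 `O=C(Nc1ccc(F)c(-c2nc3ncc(-c4ccc(F)cc4F)cc3[nH]2)c1)N1CCCC1`, which carries 2,4-difluorophenyl, gives 9500 nM. Compound 2 `O=C(Nc1ccc(F)c(-c2nc3ncc(-c4cccnc4F)cc3[nH]2)c1)N1CCCC1`, which carries 2-fluoropyridin-3-yl at that spot, gives 25600 nM, the higher of the two numbers. For the measured compounds named here, this swap is the only measured step: a 2.7-fold higher number from compound 1 to compound 2 (0.43 log units; beyond the scatter).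

Compound 3 `O=C(Nc1ccc(F)c(-c2nc3ncc(-c4cc(F)cc(F)c4)cc3[nH]2)c1)N1CCCC1` changes the same spot again, with 3,5-difluorophenyl in place of 2-fluoropyridin-3-yl on an aromatic carbon. The ring that enters is again a difluorophenyl of carbon only, as in compound 1, although its two fluorines sit differently. Going by the values given here, compound 1, at 9500 nM, is therefore the closest guide, and the single step of a 2.7-fold higher number from compound 1 to compound 2 (0.43 log units; beyond the scatter) gives the expected size, run in reverse. In this assay the expected change is modest and downward: a 2.6-fold lower number from compound 2 to compound 3 (0.41 log units; beyond the scatter). One step is thin evidence, and nothing measured yet shows what moving the fluorines does, so the range must stay wide. The estimated value for compound 3 is 10000 nM, with an expected range from 4000 nM to 25000 nM.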

Compound 3, maximal plasma concentration: 4800 nM
Compound 3: the middle estimate sits 2.1-fold (0.32 log units) above what was measured; the range from low to high includes it.
By their numbers in this assay, from the lowest: compounds 3 and 1 (each within the scatter of the next); then compound 2.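

Moving from the 2-fluoropyridin-3-yl ring to a second difluorophenyl ring in this assay gives a 5.3-fold lower number from compound 2 to compound 3 (0.73 log units; beyond the scatter) and so takes away the high number of compound 2. The earlier compounds shown here could not show what rearranging the fluorines does, and a 2.0-fold lower number from compound 1 to compound 3 (0.30 log units; within the scatter) means that no difference can be claimed between 2,4-difluorophenyl and 3,5-difluorophenyl at this position. Among these three compounds, the ring with a nitrogen stands apart from the two rings of carbon only, although nothing measured alongside these numbers offers an explanation.

The swap from compound 2 to compound 3 changes the ring nitrogen and the number of fluorines together, so the effect of each one cannot be separated, and a plain pyridin-3-yl or a monofluorophenyl ring would be needed to pull them apart. As far as these compounds go, it also remains open how the position would respond to a group of a different kind, such as a morpholine, an amine or a carboxylic acid.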